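Swapping furan for thiophene on compound 1

The compounds below may be only part of what the source reports. "The series", "measured", "known", "first", "only" and "open" are said of these compounds alone.

In a functional assay on SNU-638 cells (Homo sapiens) for cytotoxicity, read by MTT assay (on this read-out lower numbers stand for stronger inhibition and higher numbers for weaker inhibition), compound 1 `COc1ccc(/C=C/C(=O)c2ccco2)cc1Br` gives 4290 nM, the lower of the two actual numbers available. Compound 2 `COc1cc(O)ccc1/C=C/C(=O)c1ccc(NC(C)=O)cc1` gives 17400 nM, a weaker result by a gap beyond the usual scatter. Compound 3 `O=C(/C=C/c1ccc(N2CCCC2)cc1)c1ccc(F)cc1` reads > 25000 nM, which is a limit of the assay and not a number.

Compound 4 `COc1ccc(/C=C/C(=O)c2cccs2)cc1Br` has not been measured. It carries thiophen-2-yl in place of furan-2-yl on a carbonyl carbon. Among the measured compounds shown here, no measured pair shows this swap, so in this assay the expectation is a change within the scatter, with no favoured direction. The estimated step is a 1.1-fold lower number from compound 1 to compound 4 (0.03 log units; within the scatter). Compound 4 is expected to give about 4000 nM, with an estimated range from 1800 nM to 10000 nM.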

Compound 4, half-maximal inhibitory concentration: 16600 nM
Compound 4: middle estimate off by 4.2-fold (0.62 log units), on the low side, outside the stated range (above it).
By their numbers in this assay, from the lowest: compound 1; then compounds 4 and 2 (each within the scatter of the next). At a limit, above all of these: compound 3.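

In this assay, the group on the carbonyl carbon matters: with the rest of compound 1 unchanged, thiophen-2-yl in place of furan-2-yl gives a 3.9-fold higher number from compound 1 to compound 4 (0.59 log units; beyond the scatter) as the step. The two groups have the same heavy-atom count, ring size, and hydrogen-bond donor and acceptor counts, and differ in one ring atom, oxygen or sulfur, so these counts alone do not foretell the step. Nothing measured here gives a reason for it.

Still open, as far as these compounds go, is how a phenyl ring or a pyridine ring on the same carbonyl carbon would read, and whether a methyl group on the furan ring would keep the reading of compound 1.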